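Replacing cyclohexyloxy with methyl in a growth inhibitor

The compounds below may be only part of what the source reports. "The series", "measured", "known", "first", "only" and "open" are said of these compounds alone.

Compound 1 `c1cc(OC2CCCCC2)ccc1NC1=NCCO1` gives 12600 nM
Compound 2 `O=C(CCl)NC(=O)Nc1ccc(OC2CCCCC2)cc1` gives 3100 nM
Compound 3 `O=C(CCl)NC(=O)Nc1ccc(OCc2ccccc2)cc1` gives 2600 nM

All three values come from a functional assay on HT-29 cells (Homo sapiens) for inhibition, read by sulforhodamine B assay, with a stated time of 48 h; a lower number here means a stronger inhibitor of growth, a higher number a weaker inhibitor of growth. Compound 2 belongs to the lower pair of numbers: its nearest step is a 1.2-fold lower number from compound 2 to compound 3 (0.08 log units; within the scatter), and its furthest is a 4.1-fold lower number from compound 1 to compound 2 (0.61 log units; beyond the scatter).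

Compound 4 `Cc1ccc(NC(=O)NC(=O)CCl)cc1` differs from compound 2 in one place: methyl in place of cyclohexyloxy on an aromatic carbon. This puts methyl in place of cyclohexyloxy on an aromatic carbon.

Within the data shown here, two measured steps bear on this change, both only in part. The step of a 1.2-fold lower number from compound 2 to compound 3 (0.08 log units; within the scatter) swapped cyclohexyl for benzyl at the same place, stayed within the scatter, and kept the oxygen. The step of a 4.1-fold lower number from compound 1 to compound 2 (0.61 log units; beyond the scatter) was modest, but it involved a change on the nitrogen. Among the measured compounds shown here, no measured compound lacks the group on that oxygen, so the new step is poorly defined. Compound 4 gives up far more than the swap did, so a modest move toward weaker inhibition seems likely. The estimated step is a 2.6-fold higher number from compound 2 to compound 4 (0.41 log units; beyond the scatter). For compound 4, the expected value is 8000 nM, with an estimated range from 2500 nM to 30000 nM.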

Compound 4, concentration for 50% growth inhibition: 10000 nM
For compound 4 the middle estimate is 1.3-fold (0.10 log units) below the measured one; the range from low to high includes it.
By their numbers in this assay, from the lowest: compounds 3 and 2 (each within the scatter of the next); then compounds 4 and 1 (each within the scatter of the next).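

Within this assay the change from cyclohexyloxy to methyl on the aromatic carbon weakens growth inhibition (a 3.2-fold higher number from compound 2 to compound 4 (0.51 log units; beyond the scatter)). The earlier swap of cyclohexyl for benzyl kept the oxygen and stayed within the scatter, whereas this step, though modest, lies beyond it and shows that this position is not indifferent to every change. Nothing measured here explains the loss. On these data alone, it remains open whether the oxygen, the ring or simply the size of the group accounts for the difference: a methoxy group, which keeps the oxygen without the ring, and a cyclohexyl group joined directly to the aromatic carbon, which keeps the ring without the oxygen, would help separate these. As far as these compounds go, how an amine or a carboxylic acid at this carbon would compare also remains open.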